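A few compounds are considered here, and "the series" means these few. Any claim that something is new, unique, unknown or untested is made for them only; others in the source may bear on it.

Compound 3 `CC(C)[C@H](NC(=O)CN(c1nc(Cl)nc2[nH]cnc12)C1CC1)C(=O)OCc1ccccc1` stands highest of the three measured in a functional assay on the whole organism (Tail, strain ICR) with Mus musculus as the target, in the tail flick test, with a stated time of 60 min, at a dose of 25 umol/kg by the oral route (on this read-out lower numbers stand for a weaker effect and higher numbers for a stronger effect at the one dose given), where compound 3 gives 55.5%. Compound 1 `CSCC[C@H](NC(=O)CN(c1nc(Cl)nc2[nH]cnc12)C1CC1)C(=O)OCc1ccccc1` gives 30.8% and compound 2 `CC(C)C[C@H](NC(=O)CN(c1nc(Cl)nc2[nH]cnc12)C1CC1)C(=O)OCc1ccccc1` gives 27.3%; a number 3.5 percentage points lower from compound 1 to compound 2 (within the scatter). The two steps onto compound 3 are a number 24.7 percentage points higher from compound 1 to compound 3 (beyond the scatter) and a number 28.2 percentage points higher from compound 2 to compound 3 (beyond the scatter). Compound 4 `NC(=O)CC[C@H](NC(=O)CN(c1nc(Cl)nc2[nH]cnc12)C1CC1)C(=O)OCc1ccccc1` is not yet measured; it differs from compound 3 by 2-carbamoylethyl in place of isopropyl on a saturated chain carbon bound to an amide-type nitrogen and a carbonyl carbon. Going by the values given here, no measured step brings in a carbamoyl group, so only the steps into compound 3 bear on this one: in each, isopropyl displaced a longer chain and the read-out rose. The reverse, a longer chain in place of isopropyl, is expected to lower the read-out in this assay by a comparable modest amount, a number 25.5 percentage points lower from compound 3 to compound 4 (beyond the scatter). Compound 4 is therefore estimated at 30%, in the range 10% to 50%.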

Compound 4, a percentage reported as activity, at one dose (the size of the read-out at that dose, not a potency): 33.1%
Compound 4: the middle estimate sits 3.1 percentage points below what was measured, and the stated range covers the measured number.
By their numbers in this assay, from the lowest: compounds 2, 1 and 4 (each within the scatter of the next); then compound 3.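

In this assay, 2-carbamoylethyl in place of isopropyl on this saturated chain carbon loses most of what isopropyl gave (a number 22.4 percentage points lower from compound 3 to compound 4 (beyond the scatter)), so a chain ending in a carbamoyl group does not keep the higher read-out of compound 3. The other two steps (a number 5.8 percentage points higher from compound 2 to compound 4 (within the scatter); a number 2.3 percentage points higher from compound 1 to compound 4 (within the scatter)) leave compound 4 not separable from the isobutyl and 2-(methylsulfanyl)ethyl compounds, and compound 3 remains alone above the other three. Nothing available bears on the reason for these numbers.

Open, on these data alone, is whether a sec-butyl or tert-butyl group on this carbon holds the read-out of compound 3, and whether a carboxylic acid or an amine at the chain end departs from compound 4.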